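Predicting a tolyl-triazole analogue in a colon cancer cell assay

The source may hold more compounds than are shown below. What is called first, only, known or untested is meant among the compounds shown, and "the series" means these compounds.

Measured compounds:
- compound 1 `O=C1O[C@H]([C@@H](O)Cn2cc(-c3ccc(Br)cc3)nn2)C(OCc2ccccc2)=C1OCc1ccccc1`: 3760 nM
- compound 2 `CCCCCCCCCCc1cn(C[C@H](O)[C@H]2OC(=O)C(OCc3ccccc3)=C2OCc2ccccc2)nn1`: 45200 nM
- compound 3 `O=C1O[C@H]([C@@H](O)Cn2cc(CNS(=O)(=O)c3ccc(Cl)cc3)nn2)C(OCc2ccccc2)=C1OCc1ccccc1`: 18000 nM

All three share one core and differ only in the group on the five-membered ring with three nitrogens. In a functional assay on SW-620 cells (Homo sapiens) for antiproliferative activity, read by MTT assay, with a stated time of 72 h (on this read-out lower numbers stand for stronger inhibition and higher numbers for weaker inhibition), compound 3 gives 18000 nM, the second highest of the three numbers: there is a 2.5-fold lower number from compound 2 to compound 3 (0.40 log units; beyond the scatter), and there is a 4.8-fold higher number from compound 1 to compound 3 (0.68 log units; beyond the scatter).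

Compound 4 `Cc1ccc(-c2cn(C[C@H](O)[C@H]3OC(=O)C(OCc4ccccc4)=C3OCc3ccccc3)nn2)cc1` is not yet measured. The change is 4-methylphenyl in place of (((4-chlorophenyl)sulfonyl)amino)methyl on an aromatic carbon. The step that bears most on it is the one in the opposite direction, a 4.8-fold higher number from compound 1 to compound 3 (0.68 log units; beyond the scatter), where a flat aromatic group on that ring carbon was replaced by the sulfonamide-bearing chain. Compound 4 restores a flat aromatic group of the same kind as in compound 1, so a step of similar size back toward the lower number is expected. The step of a 12-fold higher number from compound 1 to compound 2 (1.08 log units; beyond the scatter) shows that a long chain in that place gives a much higher number, which compound 4 avoids. The expected step is therefore a 4.0-fold lower number from compound 3 to compound 4 (0.60 log units; beyond the scatter). Compound 4 is estimated at 4500 nM, with a range from 1500 nM to 14000 nM.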

Compound 4, half-maximal inhibitory concentration: > 100000 nM
Compound 4: only a limit was reported (the forecaster's own chance of this, stated with the estimate: 5%); middle value at least 22-fold (1.34 log units) from the limit.
By their numbers in this assay, from the lowest: compound 1; then compound 3; then compound 2. At a limit, above all of these: compound 4.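

In this assay compound 4 gives only a limit of the assay, not a number: the limit of > 100000 nM in this assay, at which 1 of the 4 values shown sits.

The clearest comparison is with compound 1, where methyl stands in place of bromo and there is an at least 26-fold higher number from compound 1 to compound 4 (1.42 log units; beyond the scatter), so an aromatic group on this ring carbon does not by itself bring the low number; the small group carried on that aromatic ring matters greatly. The earlier order also breaks, with an at least 5.5-fold higher number from compound 3 to compound 4 (0.74 log units; beyond the scatter) and an at least 2.2-fold higher number from compound 2 to compound 4 (0.34 log units; beyond the scatter), so 4-methylphenyl gives a higher number than either the sulfonamide-bearing chain or decyl, and compound 1 alone keeps its aromatic group at the low end.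

Going by these compounds, whether fluoro or methoxy in place of the bromo would keep the low number stays open. The compounds shown also cannot tell what lies behind this sharp difference between bromo and methyl.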